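A few compounds are considered here, and "the series" means these few. Any claim that something is new, unique, unknown or untested is made for them only; others in the source may bear on it.

Working notes on the hydroxamate series. Compound 2 `CN(C)c1ccc(C(=O)N[C@@H](CCCCCC(=O)NO)C(=O)Nc2cccc3cccnc23)cc1` holds the lower of the two numbers in a functional assay on NFF cells (Homo sapiens) for antiproliferative activity; a higher number here means a weaker inhibitor, a lower number a stronger inhibitor: in this assay compound 2 gives 570 nM, whereas compound 1 `CN(C)c1ccc(C(=O)N[C@@H](CCCCCC(=O)NO)C(=O)NCc2ccccn2)cc1` gives 33000 nM. Among the measured compounds shown here, the single measured step, a 58-fold lower number from compound 1 to compound 2 (1.76 log units; beyond the scatter), concerns the substituent on the amide-type nitrogen and nothing else. Compound 3 `CC(C)COC(=O)N[C@@H](CCCCCC(=O)NO)C(=O)Nc1cccc2cccnc12` keeps that quinolin-8-yl amide and changes the cap instead: isobutoxy in place of 4-(dimethylamino)phenyl on a carbonyl carbon. For the measured compounds named here, no measured pair covers an exchange at this carbonyl carbon, so the step from compound 1 to compound 2 offers no direct guide to size or direction here; it only shows that the part compound 2 and compound 3 share is the part that carried the large gain. With nothing to anchor it, a step of modest size and uncertain direction is expected, with a wide range. Compound 3 is estimated at 1200 nM, with a range of 300 nM to 5000 nM. The expected step is a 2.1-fold higher number from compound 2 to compound 3 (0.32 log units; beyond the scatter).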

Compound 3, half-maximal inhibitory concentration: 81 nM
Estimate against measurement, compound 3: 15-fold (1.17 log units) above; the whole stated range lies above it.
By their numbers in this assay, from the lowest: compound 3; then compound 2; then compound 1.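

With the quinolin-8-yl amide held fixed, the carbonyl carbon whose other neighbour is the amide-type nitrogen proves to be a responsive position in this assay, where isobutoxy in place of 4-(dimethylamino)phenyl gives a 7.0-fold lower number from compound 2 to compound 3 (0.85 log units; beyond the scatter) and the direction favours the smaller group. An aromatic ring on this carbonyl carbon is therefore not required for a number in this range, as isobutoxy has no ring and fewer heavy atoms than the group it replaces. Nothing available accounts for this gain.

Going by these compounds, it remains open whether isobutoxy gives a step of similar size and direction on the (pyridin-2-yl)methyl amide. Also open, on these data alone, is how benzyloxy, tert-butoxy or a plain alkyl chain on the same carbonyl carbon would compare with isobutoxy.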